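Swapping the aryl group on the sulfonamide nitrogen

A few compounds are considered here, and "the series" means these few. Any claim that something is new, unique, unknown or untested is made for them only; others in the source may bear on it.

Three measured compounds share one core and differ only in the aryl group on the sulfonamide nitrogen. In a functional assay on M21 cells (Homo sapiens) for antiproliferative activity, read by sulforhodamine B assay, with a stated time of 48 h (on this read-out lower numbers stand for stronger inhibition and higher numbers for weaker inhibition), compound 1 `COc1ccc(NS(=O)(=O)c2ccc(N3CCNC3=O)cc2)cc1` gives 580 nM, compound 2 `CCc1ccc(NS(=O)(=O)c2ccc(N3CCNC3=O)cc2)cc1` gives 480 nM, and compound 3 `O=C1NCCN1c1ccc(S(=O)(=O)Nc2ccc(F)c(F)c2)cc1` gives 220 nM, the lowest number of the three. Compound 4 `Cc1cccc(NS(=O)(=O)c2ccc(N3CCNC3=O)cc2)c1C` carries 2,3-dimethylphenyl in place of 3,4-difluorophenyl on a sulfonamide nitrogen. Going by the values given here, the steps that bear on this are a 2.6-fold lower number from compound 1 to compound 3 (0.42 log units; beyond the scatter) and a 2.2-fold lower number from compound 2 to compound 3 (0.34 log units; beyond the scatter), both modest moves toward lower numbers when 3,4-difluorophenyl replaced an alkyl- or methoxy-bearing phenyl. Reversing that direction with 2,3-dimethylphenyl is therefore expected to give a modest rise, a 2.0-fold higher number from compound 3 to compound 4 (0.31 log units; beyond the scatter), since compounds 1 and 2 sat higher than compound 3. Compound 4 is estimated at 450 nM, with a range of 200 nM to 1000 nM.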

Compound 4, half-maximal inhibitory concentration: 110 nM
Estimate against measurement, compound 4: 4.1-fold (0.61 log units) above; the whole stated range lies above it.
By their numbers in this assay, from the lowest: compounds 4 and 3 (each within the scatter of the next); then compounds 2 and 1 (each within the scatter of the next).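

In this assay the step of a 2.0-fold lower number from compound 3 to compound 4 (0.30 log units; within the scatter) shows that a ring with no fluorine can stand level with 3,4-difluorophenyl on the sulfonamide nitrogen, so fluorine is not required here. Compound 1 and compound 2 also lack fluorine, yet 2,3-dimethylphenyl gives a 4.4-fold lower number from compound 2 to compound 4 (0.64 log units; beyond the scatter) and a 5.3-fold lower number from compound 1 to compound 4 (0.72 log units; beyond the scatter) among these compounds, so the absence of fluorine does not by itself set a higher number. Nothing available explains these differences.

Still open, as far as these compounds go, is how an aryl group carrying an amine or a carboxylic acid would behave on this nitrogen. Also open is where an unsubstituted phenyl would fall among these compounds.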